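Hydroxyaryl hydrazone in place of a dimethylaminophenyl group

The source may report more compounds than this note shows. Statements on the series, on what has been measured and on what is new or still open speak of the compounds shown alone.

Compound 1 `CCCSc1nc(N/N=C/c2ccc(N(C)C)cc2)c2nnn(Cc3ccccc3)c2n1`: 20000 nM
Compound 2 `C#CCSc1nc(N/N=C(\C)c2ccccc2O)c2nnn(Cc3ccccc3)c2n1`: 5250 nM
Compound 3 `C#CCSc1nc(N/N=C/c2ccc(N(C)C)cc2)c2nnn(Cc3ccccc3)c2n1`: 31300 nM

In a functional assay on ECa-109 cells (Homo sapiens) for antiproliferative activity, read by MTT assay, with a stated time of 72 h (on this read-out higher numbers stand for weaker inhibition and lower numbers for stronger inhibition), compound 1 gives 20000 nM, the second highest of the three numbers. Within the data shown here, its nearest neighbour is compound 3, which gives 31300 nM, and the only single-point step among the measured compounds is a 1.6-fold higher number from compound 1 to compound 3 (0.19 log units; within the scatter), which concerns the chain on the sulfur and not the aryl group. Compound 2 gives 5250 nM, the lowest number shown, but it differs from compound 1 in more than one place, so no step to it is counted.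

Compound 4 `CCCSc1nc(N/N=C/c2c(O)ccc3ccccc23)c2nnn(Cc3ccccc3)c2n1` carries 2-hydroxynaphthalen-1-yl in place of 4-(dimethylamino)phenyl on a carbon with a double bond to nitrogen. Among the measured compounds shown here, no measured step bears on this change directly; the only hint is that compound 2, the one measured compound with a hydroxyl on its aryl group, gives a lower number than compound 1 or compound 3. On that thin basis the author expects a moderately lower number, a 2.5-fold lower number from compound 1 to compound 4 (0.40 log units; beyond the scatter), with wide uncertainty. Compound 4 is therefore estimated at 8000 nM, in the range 2500 nM to 25000 nM.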

Compound 4, half-maximal inhibitory concentration: 9290 nM
For compound 4 the middle estimate is 1.2-fold (0.06 log units) below the measured one; the measured number falls inside the stated range.
By their numbers in this assay, from the lowest: compounds 2 and 4 (each within the scatter of the next); then compounds 1 and 3 (each within the scatter of the next).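

Among these compounds, with the rest of the structure held constant, this assay gives the first direct reading of the aryl group: 2-hydroxynaphthalen-1-yl in place of 4-(dimethylamino)phenyl on a carbon with a double bond to nitrogen gives a 2.2-fold lower number from compound 1 to compound 4 (0.33 log units; beyond the scatter). The only earlier step, a 1.6-fold higher number from compound 1 to compound 3 (0.19 log units; within the scatter), concerned the chain on the sulfur, so this is the first single change shown to move the number beyond the scatter, though only modestly. Nothing measured here tells whether the second aromatic ring or the hydroxyl accounts for the step.

The compounds shown leave open whether a hydroxyl on a single phenyl ring would give a similar step, and whether a methoxy group in its place would keep it. They also leave open whether 2-hydroxynaphthalen-1-yl would give a similar step alongside the ethynyl-bearing chain on the sulfur of compound 3.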